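One methyl swapped for fluoro on a shared amide core

The compounds below may be only part of what the source reports. "The series", "measured", "known", "first", "only" and "open" are said of these compounds alone.

Compound 1 `Cc1cc(C)c(-c2ncc[nH]2)cc1NC(=O)c1ccc(OCc2ccccn2)cc1` is an amide built around a central ring that carries a 1H-imidazol-2-yl group and two methyl groups. In a functional assay on the whole organism (COLO 205 cells) for inhibition, with Mus musculus as the target, read by polymerase chain reaction, in a xenograft, with a stated time of 8 h, at a dose of 40 mg/kg by the oral route (a lower number here means less inhibition, a higher number more inhibition at the dose given (going by the name of the read-out)), compound 1 gives 88%. A close relative, compound 2 `Cc1ncc(-c2cc(NC(=O)c3ccc(OCc4ccccn4)cc3)c(C)cc2C)[nH]1`, differs only in the five-membered ring: in this assay compound 2 gives 81%. Among the measured compounds shown here, that pair gives the one measured step, a number 7 percentage points lower from compound 1 to compound 2 (within the scatter). Among the two numbers known, compound 1 holds the higher one, but the gap to compound 2 lies inside the usual scatter, so the two cannot be ranked.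

Compound 3 `Cc1cc(F)c(-c2ncc[nH]2)cc1NC(=O)c1ccc(OCc2ccccn2)cc1` has not been measured. It differs from compound 1 in this way: fluoro in place of methyl on an aromatic carbon. For the measured compounds named here, no measured step touches this position; the only known step altered the five-membered ring, not a methyl group, and stayed within the scatter. There is thus no measured basis for a shift in either direction, and none beyond the scatter is expected, that is, the step of a number 4 percentage points lower from compound 1 to compound 3 (within the scatter) is the estimate. For compound 3 the expected inhibition is 84%, with a range from 68% to 95%.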

Compound 3, a percentage reported as inhibition, in the whole organism at one dose (the size of the read-out at that dose, not a potency): 73%
The estimate for compound 3 lay 11 percentage points above the measured number; the measured number falls inside the stated range.
By their numbers in this assay, from the lowest: compounds 3, 2 and 1 (each within the scatter of the next, the first and the last beyond it).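

In this assay, putting fluoro in place of the methyl that sits ortho to a 1H-imidazol-2-yl group gives a number 15 percentage points lower from compound 1 to compound 3 (beyond the scatter). Among the compounds shown here, the earlier step, which altered only the five-membered ring, gave a number 7 percentage points lower from compound 1 to compound 2 (within the scatter), so this methyl position is the first place where a single change moves the read-out beyond the usual scatter. Neither group counts any hydrogen-bond donors or acceptors and both are a single heavy atom, so those simple counts do not separate the two, and nothing at hand shows what lies behind the drop.

From the compounds shown here alone, with only methyl and fluoro seen at this position, it remains open whether the loss belongs to fluoro in particular or would also follow with other small groups, such as chloro, methoxy or an amine. Going by these compounds, it is equally open whether the same swap would lower the number at the other methyl group, or on the compound 2 framework with its 2-methyl-1H-imidazol-5-yl ring.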